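The source may hold more compounds than are shown below. What is called first, only, known or untested is meant among the compounds shown, and "the series" means these compounds.

In a functional assay on PC-3 cells (Homo sapiens) for cytotoxicity, read by MTT assay, with a stated time of 48 h (a higher number here means a weaker inhibitor, a lower number a stronger inhibitor), compound 1 `COc1ccc(-c2c[nH]c(=O)n2-c2cc(OC)c(OC)c(OC)c2)cc1[N+](=O)[O-]` reads > 50000 nM, which is a limit and not a number. Among the compounds with values here, compound 2 `COc1ccc(-c2cn(C(=O)Nc3cc(OC)c(OC)c(OC)c3)c(=O)n2-c2cc(OC)c(OC)c(OC)c2)cc1N` gives 10000 nM, the only true number so far. Compound 3 `COc1cc(-n2c(-c3ccccc3)cn(C(C)=O)c2=O)cc(OC)c1OC` reads > 50000 nM, also only a limit. It stands at the limit of > 50000 nM in this assay, at which 2 of the 3 values shown sit.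

Compound 4 `COc1cc(-n2c(-c3ccc(Br)cc3)cn(C(C)=O)c2=O)cc(OC)c1OC` differs from compound 3 by one change, bromo in place of hydrogen on an aromatic carbon, turning phenyl into 4-bromophenyl. Within the data shown here, no measured pair shows this change, so only a small move towards stronger inhibition is expected in this assay, and the reading may well remain a limit. The estimated step of an at least 1.4-fold lower number from compound 3 to compound 4 (0.15 log units; that floor lies within the scatter) is small. Compound 4 is expected at about 35000 nM, with an estimated range of 10000 nM to 60000 nM.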

Compound 4, half-maximal inhibitory concentration: 3100 nM
Estimate against measurement, compound 4: 11-fold (1.05 log units) above, outside the stated range (below it).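

Within the data shown here, this is the first step between two compounds differing in one place: turning phenyl into 4-bromophenyl, para to a large group, gives an at least 16-fold lower number from compound 3 to compound 4 (1.20 log units; beyond the scatter) in this assay. A single added bromine at this aromatic carbon is thus enough to bring the series off the limit to a true number. Compound 3 reads only a limit, so the real step may be larger: the limit of > 50000 nM in this assay, at which 2 of the 4 values shown sit.

From the compounds shown here alone, whether chloro or a carboxylic acid at the same carbon would act like bromo stays open. So does what bromo would do elsewhere on that ring.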